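Trimming the Ethenyl Link of Compound 1

The source may report more compounds than this note shows. Statements on the series, on what has been measured and on what is new or still open speak of the compounds shown alone.

Of the compounds shown here, three have so far been measured in a functional assay on U-251 cells (Homo sapiens) for inhibition, read by MTT assay, with a stated time of 48 h (on this read-out higher numbers stand for weaker inhibition and lower numbers for stronger inhibition), and they spread widely. Here compound 1 (`C#CCN(C)CCCOc1cc(NCc2ccc(/C=C/C(=O)NO)cc2)ccc1Cl`) gives 990 nM as the lowest number of the three, which means the strongest inhibition. Compound 3 (`C#CCN(C)CCCOc1cc(NC(=O)CCCCCCC(=O)NO)c(Cl)cc1Cl`) comes next at 8670 nM and compound 2 (`C#CCN(C)CCCOc1cc(NC(=O)CCCCCCCCC(=O)NO)ccc1Cl`) reads 16200 nM in turn. Both of these numbers lie beyond the usual scatter from compound 1. However, compound 2 and compound 3 each differ from compound 1 in more than one place, so no measured pair isolates a single change.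

Compound 4 (`C#CCN(C)CCCOc1cc(NCc2ccc(C(=O)NO)cc2)ccc1Cl`) keeps the core of compound 1 and alters one thing: hydroxycarbamoyl stands in place of 2-(hydroxycarbamoyl)ethenyl on an aromatic carbon, para to a large group (hydroxycarbamoyl in place of 2-(hydroxycarbamoyl)ethenyl on an aromatic carbon). Among the measured compounds shown here, no measured step shows what this swap does, so any forecast is tentative. Compound 1 at 990 nM already sits lowest of the three, so a rise looks likelier than a fall. The estimated step is a 2.5-fold higher number from compound 1 to compound 4 (0.40 log units; beyond the scatter) in this assay and it points towards weaker inhibition, modest in size but probably just beyond the scatter. The expected value for compound 4 is 2500 nM (estimated range 800 nM to 8000 nM).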

Compound 4, half-maximal inhibitory concentration: 7120 nM
Compound 4: the middle estimate sits 2.8-fold (0.45 log units) below what was measured; the measured number falls inside the stated range.
By their numbers in this assay, from the lowest: compound 1; then compounds 4, 3 and 2 (each within the scatter of the next, the first and the last beyond it).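

Among the compounds shown here, the swap gives the first step that can be read as a single change: with hydroxycarbamoyl in place of 2-(hydroxycarbamoyl)ethenyl, this assay shows a 7.2-fold higher number from compound 1 to compound 4 (0.86 log units; beyond the scatter), a change towards weaker inhibition that lies beyond the usual scatter. The position para to a large group is therefore not indifferent to what sits there, even though the hydrogen-bond donor and acceptor counts stay the same and the group loses only its ethenyl link. Nothing at hand explains why the shorter group goes with weaker inhibition.

This one step cannot separate the loss of chain length from the loss of the double bond, and a 2-(hydroxycarbamoyl)ethyl group on the same aromatic carbon would keep the length while dropping the double bond, whereas a carboxylic acid at the end of the ethenyl link would ask how much depends on the hydroxycarbamoyl itself. Compounds 2 and 3 differ from compound 1 and compound 4 in more than one place, so their steps cannot be read.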